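A few compounds are considered here, and "the series" means these few. Any claim that something is new, unique, unknown or untested is made for them only; others in the source may bear on it.

Working notes on a short sulfonamide-piperidine series.

Three compounds have numbers in a functional assay on MIA PaCa-2 cells (Homo sapiens) for inhibition, read by MTT assay, with a stated time of 7 days; on this read-out lower numbers stand for stronger inhibition and higher numbers for weaker inhibition. Compound 1 `CCN(CC)S(=O)(=O)c1ccc(S(=O)(=O)N2CCC[C@@H](C(=O)NC3CN(C(=O)C4CC4)C3)C2)cc1` gives 2800 nM. Compound 2 `CCOC(=O)[C@@H]1C[C@H](O)CN(S(=O)(=O)c2ccc(S(=O)(=O)N(CC)CC)cc2)C1` gives 1300 nM. Compound 3 `CCOC(=O)[C@H]1CCN(S(=O)(=O)c2ccc(S(=O)(=O)N(CC)CC)cc2)C1` gives 29200 nM, the highest number of the three: its gap to compound 1 is beyond the scatter, and its gap to compound 2 is wider still and also beyond the scatter. For the measured compounds named here, no single-change pair among the measured compounds is available, so the three values stand on their own, with compound 2 differing from compound 3 in more than configuration alone.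

Compound 4 `CCOC(=O)[C@@H]1CCN(S(=O)(=O)c2ccc(S(=O)(=O)N(CC)CC)cc2)C1` is the next compound to be measured in this assay. It differs from compound 3 as follows: the two compounds have the same atoms and bonds and differ only in configuration as drawn: 1 of 1 stereo elements differ; a stereocentre at a saturated ring carbon is drawn S in compound 3 and R in compound 4. Going by the values given here, a change of configuration at a ring stereocentre in a series like this has, on other occasions, shifted numbers well beyond the scatter in either direction, and the data here hold no measured pair that fixes its size or sign. The lower number of compound 2, 1300 nM, is the only hint that another arrangement at this position is tolerated. On that basis the expected step from compound 3 to compound 4 is a 4.9-fold lower number from compound 3 to compound 4 (0.69 log units; beyond the scatter), toward a lower number, with low confidence. Compound 4 is estimated at 6000 nM, within a range of 1000 nM to 30000 nM.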

Compound 4, half-maximal inhibitory concentration: 8600 nM
Compound 4: the middle estimate sits 1.4-fold (0.16 log units) below what was measured; low and high end bracket the measured number.
By their numbers in this assay, from the lowest: compound 2; then compound 1; then compound 4; then compound 3.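

For the compounds shown here, this is the first single-change pair, and in this assay it gives the configuration at this saturated ring carbon a measured size and sign: a 3.4-fold lower number from compound 3 to compound 4 (0.53 log units; beyond the scatter). The gap can be assigned to the stereocentre alone, because nothing else separates the two structures: the fact that compounds 3 and 4 differ only in the configuration as drawn. Going by these compounds alone, the position is therefore sensitive to configuration on this read-out, with the centre drawn R carrying the lower number, although this rests on one pair and extends to no other compound.

Going by these compounds, it remains open whether the same order of the two configurations would hold with a carboxylic acid or a primary amide in place of the ethyl ester, or with a longer chain than the ethyl groups on the sulfonamide nitrogen. The contribution of the hydroxyl group in compound 2 also stays unresolved, as no compound shown pairs with it in a single change.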